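The source may report more compounds than this note shows. Statements on the series, on what has been measured and on what is new or still open speak of the compounds shown alone.

Compound 1 (`Cc1cc(NC(C)C)nc(SCc2nc3ccccc3[nH]2)n1`) stands at the weak end of the two measured compounds: in a functional assay on ECa-109 cells (Homo sapiens) for cytotoxicity, read by MTT assay, with a stated time of 72 h (a higher number here means a weaker inhibitor, a lower number a stronger inhibitor), compound 1 gives > 100000 nM, which is a limit of the assay and not a number. Compound 2 (`Cc1cc(Nc2ccc(Cl)cc2)nc(SCc2nc3ccccc3[nH]2)n1`) reads 20400 nM in this assay. Among the measured compounds shown here, the only measured step, 4-chlorophenyl in place of isopropyl on a nitrogen on an aromatic ring, is an at least 4.9-fold lower number from compound 1 to compound 2 (0.69 log units; beyond the scatter). Compound 3 (`Cc1cc(NNC(N)=S)nc(SCc2nc3ccccc3[nH]2)n1`) is changed at that same place: a group of 4 heavy atoms (1 carbon, 2 nitrogen, 1 sulfur; no ring) in place of a group of 3 heavy atoms (3 carbon; no ring), on a nitrogen on an aromatic ring. The entering group has no ring, unlike the 4-chlorophenyl of compound 2, so this single step is only a loose guide. A modest move to a lower number is expected, and a reading that stays at the limit remains possible. The expected change in this assay is an at least 2.2-fold lower number from compound 1 to compound 3 (0.34 log units; beyond the scatter). For compound 3 the estimated value is 45000 nM, with an expected range of 12000 nM to 100000 nM.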

Compound 3, half-maximal inhibitory concentration: > 100000 nM
Compound 3 gave a limit, no number; the forecaster's own chance of this, stated with the estimate: 35%; at least 2.2-fold (0.34 log units) between middle value and limit.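

In this assay, exchanging the 4-chlorophenyl on a nitrogen on an aromatic ring for the group of compound 3, which has no ring, gives an at least 4.9-fold higher number from compound 2 to compound 3 (0.69 log units; beyond the scatter). Replacing isopropyl at this place therefore does not by itself move the reading off the limit: of the two replacements shown, only the 4-chlorophenyl does. Among the compounds shown here, compound 2, at 20400 nM, holds the only actual number. The step between compound 1 and compound 3 cannot be read because both readings are limits: the limit of > 100000 nM in this assay, at which 2 of the 3 values shown sit.

Still open, from the compounds shown here alone, is whether the gain of compound 2 belongs to the ring or to its chlorine, which an unsubstituted phenyl on the same nitrogen would separate. Also open, going by these compounds, is how a benzyl group or a longer alkyl chain would read at this place.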